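The source may report more compounds than this note shows. Statements on the series, on what has been measured and on what is new or still open speak of the compounds shown alone.

Measured in a functional assay on DU-145 cells (Homo sapiens) for antiproliferative activity, read by WST assay, with a stated time of 3 days; a lower number here means a stronger inhibitor, a higher number a weaker inhibitor:
- compound 1 `CCCOc1c(-c2cc(OC)c(OC)c(OC)c2)oc2ccccc2c1=O`: 2800 nM
- compound 2 `CCCCOc1c(-c2cc(OC)c(OC)c(OC)c2)oc2ccccc2c1=O`: > 50000 nM (a limit)
- compound 3 `CCN(CC)CCCOc1c(-c2cc(OC)c(OC)c(OC)c2)oc2ccccc2c1=O`: > 50000 nM (a limit)

Compound 3 gives only a limit in this assay, not a number. The readings are bounded by the limit of > 50000 nM in this assay, at which 2 of the 3 values shown sit. The next analogue is compound 4 `CCCCN(CCCC)CCCOc1c(-c2cc(OC)c(OC)c(OC)c2)oc2ccccc2c1=O`, with the change dibutylamino in place of diethylamino on a saturated chain carbon, three bonds along the chain from an oxygen on an aromatic ring: dibutylamino in place of diethylamino.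

Going by the values given here, no measured step covers this exact swap. The closest evidence is an at least 17-fold higher number from compound 1 to compound 3 (1.25 log units; beyond the scatter), a large step on adding the diethylamino group, and an at least 17-fold higher number from compound 1 to compound 2 (1.25 log units; beyond the scatter), also large, on the same chain carbon. The step that the two limits leave unreadable from compound 2 to compound 3 cannot be read. Both readable steps run towards weaker compounds, so a return to the level of compound 1 is not expected, although the larger amine leaves some room for a measurable value. Only a small step towards a lower number is expected in this assay, and the result may again be a limit. The estimated step is an at least 1.6-fold lower number from compound 3 to compound 4 (0.22 log units; that floor lies within the scatter). For compound 4 the expected value is 30000 nM, with an estimated range of 5000 nM to 50000 nM.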

Compound 4, half-maximal inhibitory concentration: 15700 nM
Compound 4: middle estimate off by 1.9-fold (0.28 log units), on the high side; the range from low to high includes it.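

In this assay the amine end of this chain can move the read-out: dibutylamino in place of diethylamino gives an at least 3.1-fold lower number from compound 3 to compound 4 (0.50 log units; beyond the scatter), and compound 4 is the only amine shown with a measured value. Dibutylamino in place of methyl gives an at least 3.1-fold lower number from compound 2 to compound 4 (0.50 log units; beyond the scatter), yet dibutylamino in place of hydrogen gives a 5.6-fold higher number from compound 1 to compound 4 (0.75 log units; beyond the scatter), so the larger amine does not restore the level of the unsubstituted chain. Both of the first two steps are floors, and the step between compound 2 and compound 3 cannot be read, because these two compounds give only a limit: the limit of > 50000 nM in this assay, at which 2 of the 4 values shown sit.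

On these data alone, whether the value keeps dropping with a longer chain on the nitrogen, such as dihexylamino, or with a ring amine such as piperidine, remains open. As far as these compounds go, how a carboxylic acid on the same chain carbon would read also remains open.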